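The source may report more compounds than this note shows. Statements on the series, on what has been measured and on what is new or still open speak of the compounds shown alone.

Working notes on the series. Compound 1 `COc1cc(-c2cc(/C=C/C(=O)c3ccc(N)cc3)[nH]n2)cc(OC)c1OC` gives 7530 nM in a functional assay on SK-MEL-2 cells (Homo sapiens) for inhibition, read by sulforhodamine B assay, with a stated time of 48 h; on this read-out lower numbers stand for stronger inhibition of growth and higher numbers for weaker inhibition of growth. Compound 2 `COc1ccc(-c2cc(/C=C/C(=O)c3ccc(N)cc3)[nH]n2)cc1OC` gives 22200 nM in this assay; the step of a 2.9-fold higher number from compound 1 to compound 2 (0.47 log units; beyond the scatter) follows the change (hydrogen in place of methoxy on an aromatic carbon). Compound 3 `COc1cc(C(=O)/C=C/c2cc(-c3cc(OC)c(OC)c(OC)c3)n[nH]2)cc(OC)c1OC` gives 4040 nM in this assay; compound 3 and compound 1 lie within the scatter of one another, while compound 2 stands beyond it. The difference between the core of compound 3 and the core of compound 1 is not broken down here. Compound 4 `COc1ccc(-c2cc(/C=C/C(=O)c3cc(OC)c(OC)c(OC)c3)[nH]n2)cc1OC` is not yet measured; it differs from compound 3 by hydrogen in place of methoxy on an aromatic carbon, the same change as from compound 1 to compound 2, at a place described in identical words. In this assay, for the measured compounds named here, the expected step is a 2.8-fold higher number from compound 3 to compound 4 (0.45 log units; beyond the scatter), resting on the only measured instance of this change, a 2.9-fold higher number from compound 1 to compound 2 (0.47 log units; beyond the scatter). Compound 4 is therefore expected at 11500 nM, with a range from 5000 nM to 26000 nM.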

Compound 4, concentration for total growth inhibition: 7700 nM
The estimate for compound 4 lay 1.5-fold (0.17 log units) above the measured number; the range from low to high includes it.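

In this assay, hydrogen in place of methoxy on an aromatic carbon gives a 1.9-fold higher number from compound 3 to compound 4 (0.28 log units; within the scatter) on the core of compound 3. The two instances of this change cannot be told apart, so the step carried from the core of compound 1 to the core of compound 3 without a measurable difference: the same change on two cores in this assay, a 2.9-fold higher number (0.47 log units; beyond the scatter) from compound 1 to compound 2 and a 1.9-fold higher number (0.28 log units; within the scatter) from compound 3 to compound 4, 1.5-fold (0.19 log units) apart, within the scatter of two such steps. Two cores are too few for a rule, and with one of the two steps within the scatter, the data do not show that the change has a real effect on the core of compound 3.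

Going by these compounds, replacing methoxy at this place with a group other than hydrogen, such as hydroxy or ethoxy, remains open. So does whether the step holds in other cell lines.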